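The compounds below may be only part of what the source reports. "The series", "measured", "known", "first", "only" and "open" are said of these compounds alone.

Compound 1 `O=C(Nc1cccc(-n2cc(-c3ccncc3)c(-c3cc(O)cc(Cl)c3)n2)c1)Nc1ccc(Cl)c(C(F)(F)F)c1` is tested in a functional assay on A498 cells (Homo sapiens) for inhibition, read by sulforhodamine B assay, with a stated time of 48 h, tested at 0.01 uM (a lower number here means a stronger effect, a higher number a weaker effect of the compound at the concentration tested), and gives 58%. Compound 2 `O=C(Nc1cccc(-n2cc(-c3ccncc3)c(-c3cc(O)cc(Cl)c3)n2)c1)Nc1ccc(Cl)c(Cl)c1` carries chloro in place of trifluoromethyl on an aromatic carbon; in this assay compound 2 gives 57%, a step of a number 1 percentage points lower from compound 1 to compound 2 (within the scatter). Compound 3 `COc1cc(Cl)cc(-c2nn(-c3cccc(NC(=O)Nc4ccc(Cl)c(C(F)(F)F)c4)c3)cc2-c2ccncc2)c1` differs from compound 1 in its core by methyl in place of hydrogen on an oxygen on an aromatic ring; in this assay compound 3 gives 57%, a step of a number 1 percentage points lower from compound 1 to compound 3 (within the scatter). Compound 4 `COc1cc(Cl)cc(-c2nn(-c3cccc(NC(=O)Nc4ccc(Cl)c(Cl)c4)c3)cc2-c2ccncc2)c1` has not yet been measured. It differs from compound 3 by chloro in place of trifluoromethyl on an aromatic carbon, the same change that turns compound 1 into compound 2, made at the same place. For compound 4 a like step is expected, a number 1 percentage points lower from compound 3 to compound 4 (within the scatter), because the same change gave a number 1 percentage points lower from compound 1 to compound 2 (within the scatter). Compound 4 is therefore estimated to give 56% in this assay, most likely between 46% and 66%.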

Compound 4, a percentage reported as activity, at one concentration (the size of the read-out at that concentration, not a potency): 96%
Estimate against measurement, compound 4: 40 percentage points below; the whole stated range lies below it.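

Changing trifluoromethyl to chloro gives a number 39 percentage points higher from compound 3 to compound 4 (beyond the scatter) in this assay, so this change does not carry over unaltered from the core of compound 1 to the core of compound 3: the same change on two cores in this assay, a number 1 percentage points lower (within the scatter) from compound 1 to compound 2 and a number 39 percentage points higher (beyond the scatter) from compound 3 to compound 4, 40 percentage points apart, beyond the scatter of two such steps. Placing methyl on the oxygen gives a number 39 percentage points higher from compound 2 to compound 4 (beyond the scatter), so that change does not carry over either: the same change on two cores in this assay, a number 1 percentage points lower (within the scatter) from compound 1 to compound 3 and a number 39 percentage points higher (beyond the scatter) from compound 2 to compound 4, 40 percentage points apart, beyond the scatter of two such steps. The outcome of each change thus depends on the other in these four compounds, but the data do not show why, or whether this holds at other concentrations.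

Still open, on these data alone, is whether a longer chain on that oxygen would behave like the methyl. So is whether a nitrile in place of the trifluoromethyl would behave like the chloro.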